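The source may report more compounds than this note shows. Statements on the series, on what has been measured and on what is new or still open speak of the compounds shown alone.

Measured in a functional assay on HBL-100 cells (Homo sapiens) for antiproliferative activity, read by sulforhodamine B assay, with a stated time of 48 h; a higher number here means a weaker inhibitor of growth, a lower number a stronger inhibitor of growth:
- compound 1 `CCC(C)C(C#CC(=O)OC)O/C=C/C(=O)OC`: 340 nM
- compound 2 `CCOC(=O)C#CC(O/C=C/C(=O)OC)C(C)C`: 880 nM

Compound 2, at 880 nM, holds the higher of the two numbers. Compound 1, at 340 nM, lies below it by a gap beyond the usual scatter.

Compound 3 `COC(=O)C#CC(O/C=C/C(=O)OC)C(C)C` has not yet been measured. It differs from compound 2 by hydrogen in place of methyl on a saturated chain carbon bound to an oxygen next to a carbonyl group, so that ethoxycarbonyl becomes methoxycarbonyl.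

For the measured compounds named here, no measured pair shows what this change does in this assay, so the expectation has little to rest on. Going by the values given here, the only guide is the span of the two values, from compound 1 at 340 nM to compound 2 at 880 nM. A modest move towards a lower number is expected, and a result within the scatter of compound 2 would be no surprise.

The expected result is a 1.6-fold lower number from compound 2 to compound 3 (0.20 log units; within the scatter).

For compound 3 the estimate is 550 nM, with an expected range of 220 nM to 1200 nM.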

Compound 3, concentration for 50% growth inhibition: 450 nM
Estimate against measurement, compound 3: 1.2-fold (0.09 log units) above, and the stated range covers the measured number.
By their numbers in this assay, from the lowest: compounds 1, 3 and 2 (each within the scatter of the next, the first and the last beyond it).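

In this assay, for the compounds shown here, the change from ethoxycarbonyl to methoxycarbonyl, hydrogen in place of methyl on a saturated chain carbon bound to an oxygen next to a carbonyl group, gives a 2.0-fold lower number from compound 2 to compound 3 (0.29 log units; within the scatter); this is the first reading of this position, and it shows no step beyond the scatter for this single change. Compound 3 also provides a single-change link to compound 1, where hydrogen in place of methyl on a saturated chain carbon, three bonds along the chain from an oxygen on an unsaturated carbon and a triple-bonded carbon, gives a 1.3-fold higher number from compound 1 to compound 3 (0.12 log units; within the scatter). Neither step alone leaves the scatter, and nothing measured here speaks to the reason for either one.

From the compounds shown here alone, only ethoxycarbonyl and methoxycarbonyl have been seen at this position, so the effect of a longer chain such as propoxycarbonyl, or of a carboxylic acid in place of the ester, remains open. Also open, going by these compounds, is whether the two changes act independently, which a compound combining ethoxycarbonyl with the chain of compound 1 would test only together with the existing values.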